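This account rests on a few compounds, and the source may have more. Where it says the series, first, only, none or still open, it means among the compounds named here.

Within the data shown here, compound 1 `O=C1O[C@H]([C@@H](O)Cn2cc(-c3ccc(Br)cc3)nn2)C(OCc2ccccc2)=C1OCc1ccccc1` is the only member of this small set with a numerical result: in a functional assay on A549 cells (Homo sapiens) for antiproliferative activity, read by MTT assay, with a stated time of 72 h (a higher number here means a weaker inhibitor, a lower number a stronger inhibitor), compound 1 gives 750 nM. Compound 2 `CC(C)(C)OC(=O)N1CCN(C(=S)SCc2cn(C[C@H](O)[C@H]3OC(=O)C(OCc4ccccc4)=C3OCc3ccccc3)nn2)CC1` reaches only a limit of the assay, > 100000 nM. Compound 3 `O=C1O/C(=C\Cn2cc(-c3cc(C(F)(F)F)cc(C(F)(F)F)c3)nn2)C(OCc2ccccc2)=C1OCc1ccccc1` likewise stops at a limit, > 100000 nM. Two of the three recorded values thus sit at the limit of > 100000 nM in this assay, at which 2 of the 3 values shown sit, leaving compound 1 alone as a measured anchor. Compound 4 `CCCCCCCCCCc1cn(C[C@H](O)[C@H]2OC(=O)C(OCc3ccccc3)=C2OCc2ccccc2)nn1` differs from compound 1 by decyl in place of 4-bromophenyl on an aromatic carbon. Among the measured compounds shown here, no measured pair in the set matches this change, so the direction is open; a moderate loss beyond the scatter is expected, giving an estimated step of a 4.0-fold higher number from compound 1 to compound 4 (0.60 log units; beyond the scatter). Compound 4 is therefore estimated at 3000 nM, within 500 nM to 30000 nM.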

Compound 4, half-maximal inhibitory concentration: 6750 nM
For compound 4 the middle estimate is 2.3-fold (0.35 log units) below the measured one; measured number inside the range.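

Compound 4 shows that this aromatic carbon of the five-membered ring can carry decyl, a group with no ring, and still give a measured value. In this assay the change produces a 9.0-fold higher number from compound 1 to compound 4 (0.95 log units; beyond the scatter), so activity falls but a number remains. Nothing measured here gives a reason for this step. The compounds shown leave open how a shorter chain such as hexyl, or a decyl chain ending in an amine, would read at this position. They also leave open whether the step follows the bromine or the phenyl ring of 4-bromophenyl, which an unsubstituted phenyl would separate.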